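Pyridin-3-yl in place of 3-chlorophenyl on the amide

The source may report more compounds than this note shows. Statements on the series, on what has been measured and on what is new or still open speak of the compounds shown alone.

In a physicochemical assay for solubility, measured as kinetic solubility (a higher number here means a more soluble compound, a lower number a less soluble compound), compound 2 `O=C(Nc1cccc(Cl)c1)c1cc(C(F)(F)F)ccc1OCc1ccccc1` gives 7000 nM. Compound 3 `O=C(Nc1ccnnc1)c1cc(N2CCCC2)ccc1OCc1ccccc1` gives 35000 nM, which leaves compound 2 with the lower of the two actual numbers, by a gap beyond the scatter. Compound 1 `O=C(Nc1ccnnc1)c1cc(C(F)(F)F)ccc1OCc1ccccc1` gives < 1000 nM, which is a limit and not a number.

Compound 4 `O=C(Nc1cccnc1)c1cc(C(F)(F)F)ccc1OCc1ccccc1` comes next: pyridin-3-yl in place of 3-chlorophenyl on an amide-type nitrogen, with pyridin-3-yl in place of 3-chlorophenyl on an amide-type nitrogen. The measured step at this same place is an at least 7.0-fold higher number from compound 1 to compound 2 (0.84 log units; beyond the scatter), where 3-chlorophenyl replaces pyridazin-4-yl. Read in reverse, that step from compound 1 points downward when 3-chlorophenyl leaves, although pyridin-3-yl is a different group, so only part of it is expected to carry over. The step of an at least 35-fold higher number from compound 1 to compound 3 (1.54 log units; beyond the scatter) lies at another place, and compound 4 keeps the trifluoromethyl, so it bears little here.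

The expected change is a modest fall, a 2.3-fold lower number from compound 2 to compound 4 (0.37 log units; beyond the scatter). Compound 4 is estimated at 3000 nM, with an expected range of 1000 nM to 12000 nM.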

Compound 4, solubility: < 1000 nM
Compound 4 gave a limit, no number; the forecaster's own chance of this, stated with the estimate: 25%; middle value at least 3.0-fold (0.47 log units) away from the limit.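

In this assay, pyridin-3-yl on the amide-type nitrogen gives an at least 7.0-fold lower number from compound 2 to compound 4 (0.84 log units; beyond the scatter), so this position moves the read-out even when the trifluoromethyl stays in place. From the compounds shown here alone, the value of compound 4 is a limit and not a number, so the true size of this fall stays unknown. Among the compounds that keep trifluoromethyl, only 3-chlorophenyl on this nitrogen yields an actual number, and the step between pyridazin-4-yl and pyridin-3-yl cannot be read, because compound 1 and compound 4 both stand at the same limit: the limit of < 1000 nM in this assay, at which 2 of the 4 values shown sit.

Going by these compounds, it remains open whether pyrrolidin-1-yl in place of trifluoromethyl, which gives an at least 35-fold higher number from compound 1 to compound 3 (1.54 log units; beyond the scatter), would act in the same way on the pyridin-3-yl amide. On these data alone, a morpholine at that place, or a carboxylic acid on the ring carried by the amide-type nitrogen, also remains open.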